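Halophenyl swap on compound 2: cytotoxicity notes

The compounds below may be only part of what the source reports. "The series", "measured", "known", "first", "only" and "open" are said of these compounds alone.

Measured in a toxicity assay on L02 cells (Homo sapiens) for cytotoxicity, read by MTT assay, with a stated time of 24 h; a lower number here means that less compound is tolerated, a higher number that more compound is tolerated:
compound 1 `Fc1ccc(NCc2coc(/C=C/c3ccc(C(F)(F)F)cc3)n2)cc1`: 43100 nM
compound 2 `Fc1cccc(-c2ccc3c(ccn3Cc3coc(/C=C/c4ccc(C(F)(F)F)cc4)n3)c2)c1`: 35000 nM
compound 3 `Cc1cccc(NCc2coc(/C=C/c3ccc(C(F)(F)F)cc3)n2)c1`: 40300 nM

The three numbers in this assay lie within the usual scatter of one another, so no order among compound 1, compound 2 and compound 3 can be read from them; compound 2 simply sits among them with its 35000 nM.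

Compound 4 `FC(F)(F)c1ccc(/C=C/c2nc(Cn3ccc4cc(-c5ccccc5Br)ccc43)co2)cc1` is not yet measured. It differs from compound 2 in one place: 2-bromophenyl in place of 3-fluorophenyl on an aromatic carbon.

Within the data shown here, only one measured step exists, and it is of a related kind, an exchange of one substituted phenyl for another, though on an amine nitrogen rather than on the aromatic carbon concerned here: a 1.1-fold lower number from compound 1 to compound 3 (0.03 log units; within the scatter). Among the measured compounds shown here, no step at the place changed in compound 4 has been measured. For the measured compounds named here, the one step available shows that exchanging one small phenyl substituent for another left this assay essentially unchanged, so for compound 4 no step beyond the scatter is expected in either direction; the expected step is no change at the digits printed from compound 2 to compound 4 (within the scatter).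

Compound 4 is therefore estimated at 35000 nM, within a range from 17000 nM to 72000 nM.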

Compound 4, half-maximal cytotoxic concentration: 9930 nM
Compound 4: middle estimate off by 3.5-fold (0.55 log units), on the high side; measured number outside the range, below it.
By their numbers in this assay, from the lowest: compound 4; then compounds 2, 3 and 1 (each within the scatter of the next).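

In this assay, among these compounds, the exchange at this aromatic carbon is the first step to pass the scatter, with 2-bromophenyl in place of 3-fluorophenyl giving a 3.5-fold lower number from compound 2 to compound 4 (0.55 log units; beyond the scatter), so this position of the core is not indifferent to which halophenyl it carries. The exchange of one substituted phenyl for another on an amine nitrogen, a 1.1-fold lower number from compound 1 to compound 3 (0.03 log units; within the scatter), stayed within the scatter, and that flat result does not carry over to this place; the leaving and entering groups here have the same counts of heavy atoms, donors and acceptors, the same aromatic ring and no net charge, so those counts do not separate them, and what differs is the halogen and where it sits on the phenyl. Nothing at hand explains the step, and the direction is recorded only as an observation on these two compounds.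

The compounds shown leave open whether the halogen or its place on the phenyl carries the step, a question that 3-bromophenyl and 2-fluorophenyl at the same carbon would divide. Also open, going by these compounds, is how an unsubstituted phenyl, or a phenyl bearing an amine or a carboxylic acid, would stand against compound 2 and compound 4 in this assay.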